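Thiophene Ether Replaces Pyridylethyl Ether on a Shared Core

The source may hold more compounds than are shown below. What is called first, only, known or untested is meant among the compounds shown, and "the series" means these compounds.

Measured compounds:
- compound 1 `O=C1N=C(O)S/C1=C\c1ccc(OCCc2ccccn2)cc1`: 660 nM
- compound 2 `O=C1NC(=O)/C(=C/c2ccc(OCCC3CCCCO3)cc2)S1`: 750 nM

Going by the values given here, in an assay for inhibition of 15-hydroxyprostaglandin dehydrogenase [NAD(+)] (Homo sapiens), read by fluorescence and spectrophotometry (on this read-out higher numbers stand for weaker inhibition and lower numbers for stronger inhibition), compound 1 gives 660 nM, the lowest of the two numbers so far. Compound 2 gives 750 nM in this assay, a number that lies within the usual scatter of that of compound 1, so the two cannot be placed in any order.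

Compound 3 `O=C1N=C(O)S/C1=C\c1ccc(OCc2cccs2)cc1` is the next analogue of compound 1. It differs from compound 1 by thiophen-2-yl in place of (pyridin-2-yl)methyl on a saturated chain carbon bound to an oxygen on an aromatic ring. Among the compounds with values here, no pair of measured compounds shows the effect of this exchange, so the expectation rests on the shared core alone, which in compounds 1 and 2 tolerates two rather different side chains without a difference beyond the scatter. The expected step is a 1.5-fold higher number from compound 1 to compound 3 (0.18 log units; within the scatter), which is small and may well fall within the scatter. Compound 3 is accordingly estimated at 1000 nM in this assay, with a range from 300 nM to 3500 nM.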

Compound 3, half-maximal inhibitory concentration: 287 nM
The estimate for compound 3 lay 3.5-fold (0.54 log units) above the measured number, and the stated range ends above it.
By their numbers in this assay, from the lowest: compound 3; then compounds 1 and 2 (each within the scatter of the next).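

In this assay, thiophen-2-yl in place of (pyridin-2-yl)methyl on a saturated chain carbon bound to an oxygen on an aromatic ring gives a 2.3-fold lower number from compound 1 to compound 3 (0.36 log units; beyond the scatter), a modest step and the first in this series to pass beyond the scatter. It shows that the number at this position does respond to the group it carries, which the two earlier compounds could not show, as they do not differ in one place. The exchange alters the ring size, the hetero atom and the group as a whole at once, and nothing measured here explains the step or assigns it to any one of these changes.

Going by these compounds, whether a thiophen-3-yl, furan-2-yl or phenyl group at this place would give a similar number remains open. So does whether a longer chain carrying the thiophene ring would keep the step.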